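From oxetan-3-yl to methyl on an aromatic nitrogen

This account rests on a few compounds, and the source may have more. Where it says the series, first, only, none or still open, it means among the compounds named here.

Compound 1 `Cc1nn(C2COC2)cc1Nc1nc(N)c2c(C#N)c(N3CCC[C@H]3C)n(C)c2n1` gives 46.7 mL/min/kg
Compound 2 `Cc1c(Nc2nc(N)c3c(C#N)c(N4CCC[C@H]4C)n(C)c3n2)cnn1CC(C)(C)O` gives 30 mL/min/kg

In an ADME assay on microsomes from liver (Homo sapiens) for pharmacokinetics (on this read-out higher numbers stand for fast clearance and lower numbers for slow clearance), compound 1 and compound 2 lie within the usual scatter of each other, so compound 1 does not stand apart. Compound 3 `Cc1nn(C)cc1Nc1nc(N)c2c(C#N)c(N3CCC[C@H]3C)n(C)c2n1` has not been measured yet. It carries methyl in place of oxetan-3-yl on an aromatic nitrogen and otherwise matches compound 1. Among the measured compounds shown here, no measured pair shows this swap on its own, so no change beyond the scatter is expected. The estimated 1.3-fold lower number from compound 1 to compound 3 (0.11 log units; within the scatter) stays within that scatter. For compound 3 the expected value is 36 mL/min/kg with an estimated range from 18 mL/min/kg to 70 mL/min/kg in this test.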

Compound 3, clearance: 70 mL/min/kg
For compound 3 the middle estimate is 1.9-fold (0.29 log units) below the measured one, and the stated range covers the measured number.
By their numbers in this assay, from the lowest: compounds 2, 1 and 3 (each within the scatter of the next, the first and the last beyond it).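

Seen on its own, the swap of oxetan-3-yl for methyl on this aromatic nitrogen gives, in this assay, a 1.5-fold higher number from compound 1 to compound 3 (0.18 log units; within the scatter). At this position, then, the four-membered ring can give way to a single carbon without a change that stands clear of repeat-measurement noise. No measurement shown explains this result. Still open, on these data alone, is how this position would read with a carboxylic acid, an amine or a longer chain such as butyl, and whether any of these would give a step beyond the scatter.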